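The source may report more compounds than this note shows. Statements on the series, on what has been measured and on what is new or still open speak of the compounds shown alone.

Measured compounds:
compound 1 `CCC1c2cc(Cl)ccc2C(=O)N1c1cccnc1` — 3340 nM
compound 2 `O=C1c2ccc(Cl)cc2C(C2CC2)N1c1cccnc1` — 32500 nM
compound 3 `O=C1c2cc(F)c(Cl)cc2CCN1c1cccnc1` — 3540 nM

All three were tested in an ADME assay on cells for inhibition of cytochrome P450 11B1, mitochondrial (Homo sapiens), read by HTRF; on this read-out lower numbers stand for stronger inhibition and higher numbers for weaker inhibition. Compound 2 gives the highest number of the three, and both compound 1 and compound 3 lie far below it; the gaps from compound 2 to each of them are beyond the scatter, so compound 2 is the weakest inhibitor of the set.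

Compound 4 `CC1c2cc(Cl)ccc2C(=O)N1c1cccnc1` has not yet been measured. It differs from compound 2 as follows: methyl in place of cyclopropyl on a saturated ring carbon. Within the data shown here, one measured step bears directly on this change: a 9.7-fold higher number from compound 1 to compound 2 (0.99 log units; beyond the scatter). Because a 9.7-fold higher number from compound 1 to compound 2 (0.99 log units; beyond the scatter) came with cyclopropyl entering in place of the smaller ethyl, the reverse move to the still smaller methyl in compound 4 is expected to lower the number by a comparable amount, bringing it back near compound 1. Compound 4 is therefore estimated at 3500 nM, with a range from 1200 nM to 10000 nM. This estimate means an expected step of a 9.3-fold lower number from compound 2 to compound 4 (0.97 log units; beyond the scatter).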

Compound 4, half-maximal inhibitory concentration: 1250 nM
Compound 4: middle estimate off by 2.8-fold (0.45 log units), on the high side, and the stated range covers the measured number.
By their numbers in this assay, from the lowest: compound 4; then compounds 1 and 3 (each within the scatter of the next); then compound 2.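

In this assay, the move from cyclopropyl to methyl on this saturated ring carbon gives a 26-fold lower number from compound 2 to compound 4 (1.41 log units; beyond the scatter) and so spans more than the earlier comparison of ethyl with cyclopropyl. Shortening the ethyl chain to methyl also matters, with a 2.7-fold lower number from compound 1 to compound 4 (0.43 log units; beyond the scatter), so this position responds to a change within open chains and not only to the loss of the three-membered ring. Among the three compounds that differ here, the numbers rise from methyl through ethyl to cyclopropyl, and none of them goes against that order.

Going by these compounds, it remains open whether that order extends to a longer chain such as propyl, and what an aminomethyl or hydroxymethyl group would give on this carbon. Nothing shown gives a reason for these steps.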